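Naphthyl swap at the imine carbon of compound 2

The source may report more compounds than this note shows. Statements on the series, on what has been measured and on what is new or still open speak of the compounds shown alone.

Measured so far:
compound 1 `COc1ccc(C2CC(c3ccc4ccccc4c3)=NN2C2=NC(=O)/C(=C3\C(=O)Nc4ccccc43)S2)cc1`: 670 nM
compound 2 `COc1ccc(C2=NN(C3=NC(=O)/C(=C4\C(=O)Nc5ccccc54)S3)C(c3ccc(Cl)cc3)C2)cc1`: 77500 nM

In a functional assay on cells (Cancer cell lines, Homo sapiens) for cytotoxicity, read by sulforhodamine B assay, with a stated time of 48 h (on this read-out lower numbers stand for stronger inhibition of growth and higher numbers for weaker inhibition of growth), compound 1 gives 670 nM, while compound 2 gives 77500 nM, the highest of the two numbers, and the gap between the two compounds lies beyond the scatter. Among the compounds with values here, the two compounds differ in more than one place, so no single step is assigned to that gap.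

Compound 3 `O=C1N=C(N2N=C(c3ccc4ccccc4c3)CC2c2ccc(Cl)cc2)S/C1=C1/C(=O)Nc2ccccc21` is not yet measured. Its change from compound 2 is naphthalen-2-yl in place of 4-methoxyphenyl on a carbon with a double bond to nitrogen, in words naphthalen-2-yl in place of 4-methoxyphenyl on a carbon with a double bond to nitrogen. Compound 3 thereby carries the same naphthalen-2-yl group that compound 1 carries at that carbon, but keeps the 4-chlorophenyl group of compound 2.

A large step downward in this assay is expected, a 31-fold lower number from compound 2 to compound 3 (1.49 log units; beyond the scatter), because compound 1 with the naphthalen-2-yl group gives 670 nM. For compound 3 the estimate is 2500 nM, with a range from 400 nM to 15000 nM.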

Compound 3, concentration for 50% growth inhibition: 8800 nM
Compound 3: the middle estimate sits 3.5-fold (0.55 log units) below what was measured; low and high end bracket the measured number.
By their numbers in this assay, from the lowest: compound 1; then compound 3; then compound 2.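

In this assay, the naphthalen-2-yl group on the carbon with a double bond to nitrogen is better than 4-methoxyphenyl when a 4-chlorophenyl group sits on the other ring atom, giving an 8.8-fold lower number from compound 2 to compound 3 (0.94 log units; beyond the scatter). With naphthalen-2-yl held fixed, the aryl group on that other ring atom also matters: chloro in place of methoxy on its aromatic carbon gives a 13-fold higher number from compound 1 to compound 3 (1.12 log units; beyond the scatter), so this second site affects growth inhibition at least as strongly in this pair. Nothing here bears on why either step arises.

The compounds shown give the naphthalen-2-yl step only with the 4-chlorophenyl group present, so its size with a 4-methoxyphenyl group there remains open. Also open, going by these compounds, is how a naphthalen-1-yl group at the first site, or a dimethylamino group in place of chloro at the second, would read.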